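The source may hold more compounds than are shown below. What is called first, only, known or untested is meant among the compounds shown, and "the series" means these compounds.

The three measured compounds share a core: compound 1 is `Cc1cc(Br)c2oc(=O)c(-c3ccccc3)cc2c1`, compound 2 is `COc1ccc(-c2cc3cc(C)cc(Br)c3oc2=O)cc1` and compound 3 is `COc1cc(OC)cc(-c2cc3cc(C)cc(Br)c3oc2=O)c1`. In an in vitro assay on cells for inhibition of Amine oxidase [flavin-containing] B (Homo sapiens) (a higher number here means a weaker inhibitor, a lower number a stronger inhibitor), compound 1 gives 11100 nM, compound 2 gives 3230 nM and compound 3 gives 7120 nM. Compound 3 thus stands second highest of the three numbers; its gap to compound 1 lies within the scatter, while compound 2 sits beyond the scatter below it.

The change under study carries compound 3 to compound 4, whose structure is `COc1cc(-c2cc3cc(C)cc(Br)c3oc2=O)cc(OC)c1OC`. It is methoxy in place of hydrogen on an aromatic carbon. Within the data shown here, one measured step bears on it: a 3.4-fold lower number from compound 1 to compound 2 (0.54 log units; beyond the scatter), which was likewise a methoxy in place of a hydrogen on an aromatic carbon. Compounds 2 and 3, however, show that a second methoxy did not repeat that gain, their numbers lying beyond the scatter apart with compound 3 the higher. With two precedents pointing opposite ways, the third methoxy is expected to give a step of a 1.3-fold lower number from compound 3 to compound 4 (0.11 log units; within the scatter) in this assay, likely no more than modest in either direction. Compound 4 is therefore estimated at 5500 nM, within a range from 2000 nM to 16000 nM.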

Compound 4, half-maximal inhibitory concentration: 4890 nM
Estimate against measurement, compound 4: 1.1-fold (0.05 log units) above, within the range that was stated.
By their numbers in this assay, from the lowest: compounds 2, 4, 3 and 1 (each within the scatter of the next, the first and the last beyond it).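

In this assay, putting a methoxy in place of hydrogen on this aromatic carbon, ortho to two methoxy groups and para to a large group, gives a 1.5-fold lower number from compound 3 to compound 4 (0.16 log units; within the scatter). This position therefore takes a methoxy with no shift that can be told apart from the ordinary spread of repeated measurements, even with methoxy groups ortho to it on both sides. The earlier step alone might have suggested that a methoxy reliably lowers the number, but the two steps for this change are not firmly different from each other, so they give no sound basis for saying that its effect depends on the rest of the molecule: the same change on two cores in this assay, a 3.4-fold lower number (0.54 log units; beyond the scatter) from compound 1 to compound 2 and a 1.5-fold lower number (0.16 log units; within the scatter) from compound 3 to compound 4, 2.4-fold (0.37 log units) apart, within the scatter of two such steps.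

The compounds shown carry only hydrogen or methoxy at this carbon, so it remains open whether a hydroxyl, an amine, a carboxylic acid or a longer chain such as butoxy would be tolerated equally well or would move the number clearly in either direction. Going by these compounds, it also remains open how this change would behave with the bromine or the methyl on the shared core replaced by another group.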